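The source may report more compounds than this note shows. Statements on the series, on what has been measured and on what is new or still open speak of the compounds shown alone.

Three compounds share one core. In a functional assay on cells (T cell) for antagonist activity at C-X-C chemokine receptor type 4 (Homo sapiens), read by FLIPR and calcium flux, with a stated time of 20 min (on this read-out higher numbers stand for weaker inhibition and lower numbers for stronger inhibition), compound 1 `Cc1nc(CN2CCC(C)C2c2ccccn2)cc(N2CCN(C)CC2)n1` gives "not determined" (no result reported), so no result is available for it. In this assay compound 2 `Cc1ccc([C@@H]2CCCN2Cc2cc(N3CCN(C)CC3)nc(C)n2)nc1` gives 4.9 nM, while compound 3 `Cc1nc(CN2CCC[C@H]2c2ncccc2C)c(F)c(N2CCN(C)CC2)n1` gives 1.1 nM, the lowest of the two numbers, and its gap to compound 2 lies beyond the usual scatter. Compound 4 `Cc1nc(CN2CCC[C@H]2c2ncccc2C)c(C#N)c(N2CCN(C)CC2)n1` differs from compound 3 in one place: cyano in place of fluoro on an aromatic carbon. For the measured compounds named here, no pair of measured compounds shows this change, so there is no measured step to lean on. The expected step is a 1.4-fold higher number from compound 3 to compound 4 (0.13 log units; within the scatter), estimated as none beyond the scatter, with little movement in either direction. Compound 4 is accordingly expected to land near 1.5 nM, within a range from 0.5 nM to 5 nM.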

Compound 4, half-maximal inhibitory concentration: 1.8 nM
The estimate for compound 4 lay 1.2-fold (0.08 log units) below the measured number, and the stated range covers the measured number.
By their numbers in this assay, from the lowest: compounds 3 and 4 (each within the scatter of the next); then compound 2.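

In this assay, for the compounds shown here, putting cyano in place of fluoro on the aromatic carbon ortho to the 4-methylpiperazin-1-yl group gives a 1.6-fold higher number from compound 3 to compound 4 (0.21 log units; within the scatter), the first measured step at this position. The two groups therefore cannot be told apart on this read-out, even though cyano is the larger by heavy atoms and adds a hydrogen-bond acceptor. No measurement available gives a reason for this result.

From the compounds shown here alone, whether an amine, a carboxylic acid or a longer chain on this carbon would keep the number in the same range remains open. So does whether cyano and fluoro would stay this close with a different group elsewhere on the shared core.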